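Pyridyl vinyl sulfones: cytotoxicity notes on a four-compound set

The source may hold more compounds than are shown below. What is called first, only, known or untested is meant among the compounds shown, and "the series" means these compounds.

Measured so far, in an ADME assay on BV-2 cells (Mus musculus) for cytotoxicity, with a stated time of 24 h, tested at 10 uM; on this read-out lower numbers stand for a stronger effect and higher numbers for a weaker effect at the one concentration tested:
- compound 1, `COc1cccc(S(=O)(=O)/C=C/c2cccnc2)c1`, gives 100%
- compound 2, `COc1ccc(S(=O)(=O)/C=C/c2cccnc2)cc1`, gives 99.5%
- compound 3, `COc1cccc(S(=O)(=O)/C=C/c2ccncc2)c1`, gives 84.3%

Compound 1 and compound 2 carry different cores; the difference between the two cores is not broken down here. Their values in this assay lie within the scatter of one another, so no order between them is claimed. Compound 3 differs from compound 1 by pyridin-4-yl in place of pyridin-3-yl on a double-bonded chain carbon bound to a double-bonded chain carbon, and this change gives a number 15.7 percentage points lower from compound 1 to compound 3 (beyond the scatter), a modest step beyond the scatter.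

Compound 4, `COc1ccc(S(=O)(=O)/C=C/c2ccncc2)cc1`, is not yet measured in this assay. It differs from compound 2 by pyridin-4-yl in place of pyridin-3-yl on a double-bonded chain carbon bound to a double-bonded chain carbon, the same change as from compound 1 to compound 3, at the same place. Going by the values given here, because the one measured instance of this change gave a number 15.7 percentage points lower from compound 1 to compound 3 (beyond the scatter), a step of similar size is expected from compound 2 to compound 4, namely a number 15.5 percentage points lower from compound 2 to compound 4 (beyond the scatter). This rests on a single pair, so the expected range is kept wide. Compound 4 is therefore estimated at 84% in this assay, with the number expected to fall between 70% and 97%.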

Compound 4, a percentage reported as activity, at one concentration (the size of the read-out at that concentration, not a potency): 71%
The estimate for compound 4 lay 13 percentage points above the measured number, within the range that was stated.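

Pyridin-4-yl in place of pyridin-3-yl on a double-bonded chain carbon bound to a double-bonded chain carbon gives a number 28.5 percentage points lower from compound 2 to compound 4 (beyond the scatter) in this assay. Set beside the earlier step, the change runs in the same direction on both cores, and the two steps cannot be told apart in size: the same change on two cores in this assay, a number 15.7 percentage points lower (beyond the scatter) from compound 1 to compound 3 and a number 28.5 percentage points lower (beyond the scatter) from compound 2 to compound 4, 12.8 percentage points apart, within the scatter of two such steps. This supports carrying the change between these two cores as a lowering of the read-out, but it rests on two pairs at one concentration, so it does not show that the change would behave alike on any further core, and it gives no reason for the lowering.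

On these data alone, whether the same change holds on a core carrying an amine or a carboxylic acid remains open. Also open, as far as these compounds go, is what a longer chain in place of the double-bonded chain would do to the read-out in this assay, with either pyridinyl group.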